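The compounds below may be only part of what the source reports. "The series", "measured", "known", "first", "only" and "open" are said of these compounds alone.

Three compounds built on one shared core have been examined in an assay on CHO cells for displacement of a labelled ligand from sphingosine 1-phosphate receptor 2 (Homo sapiens); a lower number here means a stronger inhibitor, a higher number a weaker inhibitor. Compound 1 `Cc1cc(CCC(=O)O)ccc1-c1noc(-c2ccc(OC(C)C)c(C#N)c2)n1` carries a nitrile and a 2-carboxyethyl chain; in this assay compound 1 returns > 10000 nM, which is a limit of the assay rather than a number. Compound 2 `Cc1cc([C@@H]2C[C@H]2C(=O)O)ccc1-c1noc(-c2ccc(OC(C)C)c(C(F)(F)F)c2)n1` bears a trifluoromethyl and a 2-carboxycyclopropyl group, and in this assay compound 2 likewise gives only a limit, > 10000 nM. Compound 3 `Cc1cc(CC(C)C(=O)O)ccc1-c1noc(-c2ccc(OC(C)C)c(C(F)(F)F)c2)n1` keeps the trifluoromethyl and has a 2-carboxypropyl chain; in this assay compound 3 also stands at a limit, > 10000 nM. The step that the two limits leave unreadable from compound 2 to compound 3, 2-carboxypropyl in place of 2-carboxycyclopropyl on an aromatic carbon, therefore cannot be read. On the numbers shown, compound 3 stands at the limit of > 10000 nM in this assay, at which 3 of the 3 values shown sit, with nothing separating it from the others.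

Compound 4 `Cc1cc(CCC(=O)O)ccc1-c1noc(-c2ccc(OC(C)C)c(C(F)(F)F)c2)n1` differs from compound 3 by hydrogen in place of methyl on a saturated chain carbon bound to a carbonyl carbon and a saturated chain carbon. For the measured compounds named here, no measured step bears directly on this change, and the one measured step is unreadable. Since nothing measured moves off the limit, the expected step is a step that the limit leaves unreadable from compound 3 to compound 4, none beyond the scatter. The estimate for compound 4 in this assay is 20000 nM, with a range from 7000 nM to 100000 nM, most likely reported once more only as a limit.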

Compound 4, half-maximal inhibitory concentration: > 10000 nM
Compound 4 was reported as a limit; the forecaster's own chance of this, stated with the estimate: 85%; the middle value is on the limit's open side.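

In this assay compound 4 gives > 10000 nM, which is again a limit of the assay and not a number. The steps to compound 4 from compound 1, compound 2 and compound 3 therefore cannot be read, and the series stays together: the limit of > 10000 nM in this assay, at which 4 of the 4 values shown sit. The compounds shown leave open how far any of them lies from that limit, and whether any change to the shared core would give a measurable value.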